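A few compounds are considered here, and "the series" means these few. Any claim that something is new, unique, unknown or untested is made for them only; others in the source may bear on it.

Measured compounds:
compound 1 `Cc1cccc(Sc2c[nH]c3ccc(Cl)cc23)c1` gives 100000 nM
compound 2 `COc1cc(OC)cc(Sc2c[nH]c3ccc(Cl)cc23)c1` gives 7000 nM
compound 3 `COc1cc(OC)cc(Sc2c(C)[nH]c3ccc(Cl)cc23)c1` gives 45000 nM

All three were run in an assay on isolated protein for inhibition of Indoleamine 2,3-dioxygenase 1 (Homo sapiens), read by HPLC, with a stated time of 60 min, in the presence of a further agent that is not named here; on this read-out higher numbers stand for weaker inhibition and lower numbers for stronger inhibition. Compound 1 stands at the high end of the set; compound 2 sits well below it, and compound 3 lies in between. How the cores of compound 1 and compound 2 differ is not broken down here.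

One single-point change has a measured step: methyl in place of hydrogen on an aromatic carbon, which in this assay gave a 6.4-fold higher number from compound 2 to compound 3 (0.81 log units; beyond the scatter). The same kind of change is now made on compound 1 to give compound 4 `Cc1cc(C)cc(Sc2c[nH]c3ccc(Cl)cc23)c1`: methyl in place of hydrogen on an aromatic carbon. The two places are not the same. In compound 3 the methyl enters on a five-membered aromatic ring with 1 nitrogen, part of a fused or bridged system of two rings, next to the ring nitrogen and next to the ring atom that bears a large group; in compound 4 it enters on a six-membered aromatic ring of carbon only, meta to a large group and meta to a methyl group. The measured step therefore only loosely guides the new one.

For compound 4 the expected step from compound 1 is a 1.7-fold lower number from compound 1 to compound 4 (0.22 log units; within the scatter); this rests on compound 1 already giving 100000 nM, leaving little room for a higher number, while the step of a 6.4-fold higher number from compound 2 to compound 3 (0.81 log units; beyond the scatter) warns that a methyl need not help. The estimate for compound 4 in this assay is 60000 nM, expected between 15000 nM and 200000 nM.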

Compound 4, half-maximal inhibitory concentration: 20000 nM
The estimate for compound 4 lay 3.0-fold (0.48 log units) above the measured number, and the stated range covers the measured number.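

In this assay the methyl entering on the six-membered aromatic ring of carbon only, meta to a large group and meta to a methyl group, gave a 5.0-fold lower number from compound 1 to compound 4 (0.70 log units; beyond the scatter) and so ran opposite to the earlier step on the five-membered ring. Methyl in place of hydrogen on an aromatic carbon therefore does not carry from one core to another in this series as a single fixed step: the same change on two cores in this assay, a 6.4-fold higher number (0.81 log units; beyond the scatter) from compound 2 to compound 3 and a 5.0-fold lower number (0.70 log units; beyond the scatter) from compound 1 to compound 4, 32-fold (1.51 log units) apart, beyond the scatter of two such steps. The two steps differ in both core and place, and these compounds do not separate those two factors, nor can two steps set a rule for compounds beyond those shown.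

Open, going by these compounds, is whether the same methyl would give a step of the same direction on the other core, that is, on the five-membered ring of compound 1 or on the six-membered ring of compound 2, which would show whether the core or the place decides the direction. Also open, on these data alone, is whether another group on that aromatic carbon of compound 4, such as an ethyl, a hydroxyl, an amine or a carboxylic acid, would move the number the way methyl did.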